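Swapping a Chlorophenyl for a Furanyl Ring at the Amine

This account rests on a few compounds, and the source may have more. Where it says the series, first, only, none or still open, it means among the compounds named here.

Three compounds sharing one core have been measured in a functional assay on L02 cells (Homo sapiens) for inhibition, read by Griess assay, with stated times of 1 h and 24 h; on this read-out higher numbers stand for weaker inhibition and lower numbers for stronger inhibition:
Compound 1, `COc1cc(/C=C/c2nc(Nc3ccc(C(C)C)cc3)c3sccc3n2)cc(OC)c1OC`, gives 370000 nM.
Compound 2, `COc1cc(/C=C/c2nc(Nc3ccc(O)cc3)c3sccc3n2)cc(OC)c1OC`, gives only the assay limit > 1000000 nM.
Compound 3, `COc1cc(/C=C/c2nc(NCc3ccccc3Cl)c3sccc3n2)cc(OC)c1OC`, gives only the assay limit > 1000000 nM.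

Compound 3 therefore stands at the edge of what this assay can report: its value is a limit, not a number, and the limit of > 1000000 nM in this assay, at which 2 of the 3 values shown sit, shows how little of this small set is resolved. Going by the values given here, the one readable step leading to it, an at least 2.7-fold higher number from compound 1 to compound 3 (0.43 log units; beyond the scatter), runs toward weaker inhibition. The other, a step that the two limits leave unreadable from compound 2 to compound 3, cannot be sized, since both ends are limits.

Compound 4, `COc1cc(/C=C/c2nc(NCc3ccco3)c3sccc3n2)cc(OC)c1OC`, differs from compound 3 by furan-2-yl in place of 2-chlorophenyl on a saturated chain carbon bound to a nitrogen on an aromatic ring. Among the compounds with values here, no measured step touches this kind of exchange, so nothing here argues for a return to a readable number. Compound 4 is expected to sit at or near the same limit, giving an estimated 1200000 nM, with a range from 400000 nM to 4000000 nM. That estimate corresponds to an expected step that the limit leaves unreadable from compound 3 to compound 4, meaning no change beyond the scatter is anticipated.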

Compound 4, half-maximal inhibitory concentration: 189000 nM
Beside the measured number, compound 4's estimate is 6.3-fold (0.80 log units) above it, outside the stated range (below it).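

In this assay, replacing 2-chlorophenyl with furan-2-yl on the saturated chain carbon bound to a nitrogen on an aromatic ring gives an at least 5.2-fold lower number from compound 3 to compound 4 (0.72 log units; beyond the scatter), so the ring carried by this chain can move a compound off the assay limit and onto a readable number. Compared with the 4-hydroxyphenyl group on the same nitrogen, (furan-2-yl)methyl gives an at least 5.2-fold lower number from compound 2 to compound 4 (0.72 log units; beyond the scatter), which is a second readable gain in inhibition. Against compound 1 the result is a 2.0-fold lower number from compound 1 to compound 4 (0.29 log units; within the scatter), so (furan-2-yl)methyl and 4-isopropylphenyl on this nitrogen cannot be told apart in this assay, and two quite different groups turn out to give readable numbers.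

The readings of compound 2 and compound 3 are both limits, so no order between them can be read: the limit of > 1000000 nM in this assay, at which 2 of the 4 values shown sit. Also open, going by these compounds, is whether the gain comes from losing the chlorine or from changing the ring itself, a question that plain phenyl on the same chain would address, and what a longer chain carrying the furan-2-yl ring would do.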